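Swapping methylamino for methoxy on compound 3

The source may hold more compounds than are shown below. What is called first, only, known or untested is meant among the compounds shown, and "the series" means these compounds.

Of the compounds shown here, three have been tested in a functional assay on CEM-DNR-bulk cells (Homo sapiens), read by MTT assay, with a stated time of 72 h; on this read-out higher numbers stand for weaker inhibition and lower numbers for stronger inhibition. Compound 1 `COc1ncnc2c1c(I)cn2[C@@H]1O[C@H](CO)[C@@H](O)[C@H]1O` carries an iodo group on the shared core; in this assay compound 1 reaches only the limit > 20000 nM, which is not a number. Compound 2 `COc1ncnc2c1c(-c1cc3ccccc3o1)cn2[C@@H]1O[C@H](CO)[C@@H](O)[C@H]1O` replaces that iodo group with 1-benzofuran-2-yl, and in this assay compound 2 gives 10800 nM. Among the compounds with values here, that single change is the only measured step, an at least 1.8-fold lower number from compound 1 to compound 2 (0.26 log units; that floor lies within the scatter). Compound 3 `CNc1ncnc2c1c(-c1ccco1)cn2[C@@H]1O[C@H](CO)[C@@H](O)[C@H]1O` bears a furan ring and a methylamino group; in this assay compound 3 sits at the limit > 20000 nM, again not a number. On the numbers shown, compound 3 stands with compound 1 at the limit (the limit of > 20000 nM in this assay, at which 2 of the 3 values shown sit), while only compound 2 yields a figure.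

Compound 4 `COc1ncnc2c1c(-c1ccco1)cn2[C@@H]1O[C@H](CO)[C@@H](O)[C@H]1O` differs from compound 3 in one place: methoxy in place of methylamino on an aromatic carbon. No measured step alters this group; the only one known exchanges iodo for 1-benzofuran-2-yl instead, so nothing shown sizes the change directly. Compound 1, which already carries methoxy, gives only a limit, and the furan ring of compound 3 stays in place. The expected step is none beyond the scatter, an at least 1.1-fold lower number from compound 3 to compound 4 (0.04 log units; that floor lies within the scatter). Compound 4 is expected to give about 18000 nM, within 7000 nM to 45000 nM, with a fair chance that this assay again reports only a limit.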

Compound 4, half-maximal inhibitory concentration: 160 nM
Compound 4: middle estimate off by 110-fold (2.05 log units), on the high side, outside the stated range (below it).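

In this assay, the group on this aromatic carbon proves decisive once furan-2-yl is present, with an at least 120-fold lower number from compound 3 to compound 4 (2.09 log units; beyond the scatter) for methoxy in place of methylamino, so a swap of a single atom in a small group can separate a compound at the limit from a clearly active one. Methoxy held fixed, the other group counts as well, with a 68-fold lower number from compound 2 to compound 4 (1.83 log units; beyond the scatter) for furan-2-yl in place of 1-benzofuran-2-yl and an at least 120-fold lower number from compound 1 to compound 4 (2.09 log units; beyond the scatter) for furan-2-yl in place of iodo, and among these compounds activity of this size appears only where methoxy and furan-2-yl occur together, as compound 1 has the first without the second and compound 3 the second without the first. The two steps that start from a limit give only a minimum size, not an exact one: the limit of > 20000 nM in this assay, at which 2 of the 4 values shown sit.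

The compounds shown cannot tell whether the gap between methylamino and methoxy follows the hydrogen-bond donor that leaves, a question that a dimethylamino group on the same carbon would address. They also leave open whether a longer chain such as ethoxy would keep this activity, and whether methoxy would give a step of similar size alongside 1-benzofuran-2-yl or iodo.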